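Ester in place of nitrile at the chain end

This account rests on a few compounds, and the source may have more. Where it says the series, first, only, none or still open, it means among the compounds named here.

Compound 1 `CC(=O)c1cc(C(C)=O)c(OCCCCC#N)cc1O` gives 8% in an assay on isolated protein for inhibition of leukotriene B4 receptor 1 (Homo sapiens), tested at 10 uM; on this read-out higher numbers stand for more inhibition at the one concentration tested (going by the name of the read-out) and lower numbers for less inhibition. Compound 2 `C=CCc1cc(C(C)=O)c(O)cc1OCCCCCCCCC#N` gives 86% in this assay, and compound 3 `CCc1cc(C(C)=O)c(O)cc1OCCCCCC[S+](C)[O-]` gives 92% in this assay. On these three numbers compound 2 stands second highest; its gap to compound 3 lies within the scatter, while its gap to compound 1 lies beyond it. Compound 4 `C=CCc1cc(C(C)=O)c(O)cc1OCCCCCC(=O)OC` has not yet been measured in this assay. It differs from compound 2 in one place: methoxycarbonyl in place of 3-cyanopropyl on a saturated chain carbon, five bonds along the chain from an oxygen on an aromatic ring. Among the compounds with values here, no measured pair carries this change, so the step is expected to be a modest loss, a number 16 percentage points lower from compound 2 to compound 4 (beyond the scatter), possibly no larger than the scatter. For compound 4 in this assay the estimate is 70%, with a range from 40% to 92%.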

Compound 4, a percentage reported as inhibition, at one concentration (the size of the read-out at that concentration, not a potency): 106%
The estimate for compound 4 lay 36 percentage points below the measured number, and the stated range ends below it.
By their numbers in this assay, from the lowest: compound 1; then compounds 2 and 3 (each within the scatter of the next); then compound 4.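

In this assay, methoxycarbonyl in place of 3-cyanopropyl, five bonds along the chain from an oxygen on an aromatic ring, gives a number 20 percentage points higher from compound 2 to compound 4 (beyond the scatter) and so counts as a gain, not a loss. A nitrile at the chain end is therefore not needed for high inhibition in this series. Nothing measured accounts for the gain.

The end group and the chain length change together in this one step, and the pair does not separate them. From the compounds shown here alone, a carboxylic acid or an amide at the same chain end remains open.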